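Chloro to bromo swap on two related cores

The compounds below may be only part of what the source reports. "The series", "measured", "known", "first", "only" and "open" are said of these compounds alone.

Measured in a functional assay on MCF7 cells (Homo sapiens) for cytotoxicity, read by sulforhodamine B assay, with a stated time of 48 h; a higher number here means a weaker inhibitor of growth, a lower number a stronger inhibitor of growth:
compound 1 `NC(=S)N/N=C1/C(=O)N(CN2CCN(c3ccnc4cc(Cl)ccc34)CC2)c2cccc(Cl)c21`: 57500 nM
compound 2 `NC(=S)N/N=C1/C(=O)N(CN2CCN(c3ccnc4cc(Cl)ccc34)CC2)c2cccc(Br)c21`: 46600 nM
compound 3 `NC(=S)N/N=C1\C(=O)Nc2cc(Cl)ccc21`: 17200 nM

Among the measured compounds shown here, the one paired step so far is bromo in place of chloro on an aromatic carbon, which gave a 1.2-fold lower number from compound 1 to compound 2 (0.09 log units; within the scatter). The difference between the core of compound 1 and the core of compound 3 is not broken down here; compound 3 simply gives the lowest number of the three in this assay.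

Compound 4 `NC(=S)N/N=C1\C(=O)Nc2cc(Br)ccc21` is the unmeasured partner of compound 3, carrying (bromo in place of chloro on an aromatic carbon). This is the same kind of change as that from compound 1 to compound 2, not the same: there the place is ortho to a fused ring and meta to a fused ring, here it is meta to a fused ring and para to a fused ring. Because the earlier swap gave a 1.2-fold lower number from compound 1 to compound 2 (0.09 log units; within the scatter), the step expected from compound 3 to compound 4 in this assay is a 1.2-fold lower number from compound 3 to compound 4 (0.09 log units; within the scatter). Compound 4 is accordingly estimated at 14000 nM, between 7000 nM and 30000 nM.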

Compound 4, concentration for 50% growth inhibition: 17900 nM
Estimate against measurement, compound 4: 1.3-fold (0.11 log units) below; low and high end bracket the measured number.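

In this assay, bromo in place of chloro on an aromatic carbon of the core of compound 3 gives a 1.0-fold higher number from compound 3 to compound 4 (0.02 log units; within the scatter), so the two halogens are not told apart at this place. Set beside the earlier swap, the change carries from one core to the other with no difference that can be read: the same change on two cores in this assay, a 1.2-fold lower number (0.09 log units; within the scatter) from compound 1 to compound 2 and a 1.0-fold higher number (0.02 log units; within the scatter) from compound 3 to compound 4, 1.3-fold (0.11 log units) apart, within the scatter of two such steps

Among the compounds shown here, this shows only that the swap stays within the scatter on these two cores; core and place differ together between the two pairs, so their contributions cannot be separated, and nothing follows for other cores.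

The compounds shown carry only chloro and bromo at these places. On these data alone, whether a group such as methoxy, an amine or a nitrile there would shift the number remains open.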